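The source may hold more compounds than are shown below. What is called first, only, known or untested is meant among the compounds shown, and "the series" means these compounds.

Compound 1, `Cc1c(C(=O)N/N=C\c2cccnc2)oc2cccc(O)c12`: in a functional assay on PC-3 cells (Homo sapiens) for inhibition (on this read-out lower numbers stand for stronger inhibition and higher numbers for weaker inhibition), compound 1 gives >= 40000 nM, which is a limit of the assay and not a number.
Compound 2, `Cc1c(C(=O)N/N=C\c2ccccn2)oc2cccc(O)c12`: in this assay compound 2 gives >= 40000 nM, again a limit rather than a number.
Compound 3, `Cc1c(C(=O)N/N=C\c2ccc(O)cc2O)oc2cccc(O)c12`: in this assay compound 3 gives 14800 nM.

Compound 3 therefore holds the only measured number among the three; the other two sit at a limit, as shown by the limit of >= 40000 nM in this assay, at which 2 of the 3 values shown sit. Compound 4, `Cc1c(C(=O)N/N=C\c2ccc(F)cc2)oc2cccc(O)c12`, has not yet been measured. Its change from compound 3 is 4-fluorophenyl in place of 2,4-dihydroxyphenyl on a carbon with a double bond to nitrogen: both hydroxyl groups disappear and a single fluorine takes their place.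

Among the measured compounds shown here, two measured steps bear on this. The step from the pyridin-3-yl compound gave an at least 2.7-fold lower number from compound 1 to compound 3 (0.43 log units; beyond the scatter), and that from the pyridin-2-yl compound gave an at least 2.7-fold lower number from compound 2 to compound 3 (0.43 log units; beyond the scatter). For the measured compounds named here, in both, the 2,4-dihydroxyphenyl group brought the only readable number; removing it again in compound 4 is expected to move the number back upward, toward or beyond the limit. The estimated step is a 2.4-fold higher number from compound 3 to compound 4 (0.37 log units; beyond the scatter). Compound 4 is expected to give about 35000 nM, within 12000 nM to 100000 nM.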

Compound 4, half-maximal inhibitory concentration: >= 40000 nM
Compound 4: a limit, no number; the forecaster's own chance of this, stated with the estimate: 55%; middle value at least 1.1-fold (0.05 log units) from the limit.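

In this assay, 4-fluorophenyl in place of 2,4-dihydroxyphenyl on the carbon with a double bond to nitrogen gives an at least 2.7-fold higher number from compound 3 to compound 4 (0.43 log units; beyond the scatter), so the loss of a readable number does not need a pyridine ring. Compound 4 has a six-membered aromatic ring of carbon only, unlike the pyridin-3-yl of compound 1 and the pyridin-2-yl of compound 2, yet it stops at the same limit of the assay: the limit of >= 40000 nM in this assay, at which 3 of the 4 values shown sit. The steps joining compound 4 to compound 1 and to compound 2 run between two limits and cannot be read.

From the compounds shown here alone, whether both hydroxyl groups are needed stays open, and a single one, as in 2-hydroxyphenyl or 4-hydroxyphenyl, would test this. A plain phenyl or a methoxy-bearing phenyl would show whether the fluorine or the free hydroxyl hydrogens matter here.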